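Shifting the Pyridine Nitrogen: From Compound 2 to Compound 3

This account rests on a few compounds, and the source may have more. Where it says the series, first, only, none or still open, it means among the compounds named here.

Compound 1 `O=C(/C=C/c1ccccn1)c1nc2ccccc2s1`: > 100000 nM
Compound 2 `O=C(/C=C/c1ccccn1)c1nc2ccccc2[nH]1`: 340 nM

Of the compounds shown here, two have been measured in a functional assay on HepG2 cells (Homo sapiens) for antiproliferative activity, read by MTT assay, with a stated time of 48 h; a higher number here means a weaker inhibitor, a lower number a stronger inhibitor. For compound 1 the result is only a limit of the assay, > 100000 nM, not a number; this is the situation described by the limit of > 100000 nM in this assay, at which 1 of the 2 values shown sits. Compound 2 gives 340 nM in this assay. Compound 2 therefore holds the only real number shown, and the other value shown is a limit, so no ordering between the two can be read from it.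

Compound 3 `O=C(/C=C/c1cccnc1)c1nc2ccccc2[nH]1` is not yet measured. It differs from compound 2 in one place: pyridin-3-yl in place of pyridin-2-yl on a double-bonded chain carbon bound to a double-bonded chain carbon. The two share every atom and differ only in how the pyridine is attached to the double-bonded chain carbon.

Among the measured compounds shown here, no measured step of this kind is available here, so the expectation rests on compound 2 alone. The expected step is a 2.4-fold higher number from compound 2 to compound 3 (0.37 log units; beyond the scatter), a modest loss of potency with a wide range on either side. Compound 3 is estimated at 800 nM in this assay, expected to fall between 150 nM and 5000 nM.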

Compound 3, half-maximal inhibitory concentration: 8480 nM
The estimate for compound 3 lay 11-fold (1.03 log units) below the measured number; the whole stated range lies below it.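

In this assay, changing only how the pyridine is attached gives a 25-fold higher number from compound 2 to compound 3 (1.40 log units; beyond the scatter), so this position responds strongly to a change that keeps every atom and merely joins the ring differently. Among the compounds shown here, the only earlier comparison, between compound 1 and compound 2, changed the core rather than the pyridine and ended in a limit of the assay, whereas this step has a readable size and shows that pyridin-2-yl gives a much lower number than pyridin-3-yl on this double-bonded chain carbon. The two groups have the same counts of heavy atoms, hydrogen-bond donors and hydrogen-bond acceptors, and nothing measured here accounts for the gap between them.

The compounds shown leave open whether pyridin-4-yl would resemble pyridin-2-yl or pyridin-3-yl, and whether a plain phenyl ring, with no nitrogen in the ring at all, would keep the potency of compound 2 or lose it. They also leave open whether a small group such as methyl or an amine on the pyridin-2-yl ring would be tolerated, since only unsubstituted pyridine rings appear here.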